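A few compounds are considered here, and "the series" means these few. Any claim that something is new, unique, unknown or untested is made for them only; others in the source may bear on it.

In a physicochemical assay for pharmacokinetics, at pH 8 (on this read-out higher numbers stand for a longer-lived compound and lower numbers for a shorter-lived compound), compound 1 `O=C(Sc1cccnc1C(=O)O)c1ccccc1` gives 60.1 h. Compound 2 `O=C(Sc1cccnc1C(=O)O)c1cccc(Cl)c1` gives 14.8 h and compound 3 `O=C(Sc1cccnc1C(=O)O)c1ccc(Cl)cc1` gives 26.6 h, two values within the scatter of each other and both lower than that of compound 1. The steps for chloro in place of hydrogen on an aromatic carbon are a 4.1-fold lower number from compound 1 to compound 2 (0.61 log units; beyond the scatter) and a 2.3-fold lower number from compound 1 to compound 3 (0.35 log units; beyond the scatter), each modest. Compound 4 `COc1cccc(C(=O)Sc2cccnc2C(=O)O)c1` has methoxy in place of chloro on an aromatic carbon, meta to a large group (methoxy in place of chloro on an aromatic carbon). Going by the values given here, no measured step makes this exchange. Compound 4 lacks the chloro behind the label of a 4.1-fold lower number from compound 1 to compound 2 (0.61 log units; beyond the scatter), so a partial return towards compound 1 is expected, of modest size. The step expected in this assay is a 2.2-fold higher number from compound 2 to compound 4 (0.33 log units; beyond the scatter). The estimate for compound 4 is 32 h, with an expected range of 18 h to 58 h.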

Compound 4, half-life: 63.7 h
For compound 4 the middle estimate is 2.0-fold (0.30 log units) below the measured one; the whole stated range lies below it.
By their numbers in this assay, from the lowest: compounds 2 and 3 (each within the scatter of the next); then compounds 1 and 4 (each within the scatter of the next).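

At the place meta to a large group, methoxy in place of chloro gives (a 4.3-fold higher number from compound 2 to compound 4 (0.63 log units; beyond the scatter)) in this assay, so the lower number of compound 2 does not extend to every group there. Methoxy in place of hydrogen gives (a 1.1-fold higher number from compound 1 to compound 4 (0.03 log units; within the scatter)), which leaves compound 1 and compound 4 indistinguishable. No available evidence accounts for the difference between chloro and methoxy.

Open, as far as these compounds go, is whether an amine, a carboxylic acid or a longer chain at this place would match methoxy or chloro. Also open, from the compounds shown here alone, is how methoxy behaves at the place chloro holds in compound 3.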